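Swapping the sulfonyl aryl group for a chlorothiophene

This account rests on a few compounds, and the source may have more. Where it says the series, first, only, none or still open, it means among the compounds named here.

Measured so far:
- compound 1 `O=S(=O)(Nc1ccc2oc(-c3ccccc3)nc2c1)c1cccc(F)c1` gives > 100000 nM
- compound 2 `COc1ccc(Cl)cc1S(=O)(=O)Nc1ccc2oc(-c3ccccc3)nc2c1` gives > 100000 nM

The read-out is an assay on cells for inhibition of HSP60/HSP10 (Homo sapiens), with a stated time of 60 min; on this read-out lower numbers stand for stronger inhibition and higher numbers for weaker inhibition. For compound 1 the value > 100000 nM is a limit of the assay rather than a number. For compound 2 the value > 100000 nM is likewise only a limit. Compound 2 therefore stands at the upper edge of what this assay can report, as described by the limit of > 100000 nM in this assay, at which 2 of the 2 values shown sit.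

The change from compound 1 to compound 2 is a step that the two limits leave unreadable from compound 1 to compound 2, so its size cannot be read from the two limits.

Compound 3 `O=S(=O)(Nc1ccc2oc(-c3ccccc3)nc2c1)c1ccc(Cl)s1` follows from compound 2 by the change (5-chlorothiophen-2-yl in place of 5-chloro-2-methoxyphenyl on a sulfonyl sulfur). Within the data shown here, the only measured step, the one from compound 1 to compound 2, bears on a change at the same sulfonyl sulfur, but it is unreadable, so it gives no guide to the size or direction of the step to compound 3. With both measured compounds sitting at the limit, the expectation for compound 3 is that it again stays at or near that limit, an expected step that the limit leaves unreadable from compound 2 to compound 3 in this assay. The estimate for compound 3 is 150000 nM, ranging from 50000 nM to 500000 nM.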

Compound 3, half-maximal inhibitory concentration: 70000 nM
Beside the measured number, compound 3's estimate is 2.1-fold (0.33 log units) above it; the measured number falls inside the stated range.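

Compound 3 gives this position its first true reading in this assay, so a group on the sulfonyl sulfur can now be tied to a number instead of a limit. Putting 5-chlorothiophen-2-yl on that sulfur gives an at least 1.4-fold lower number from compound 2 to compound 3 (0.15 log units; that floor lies within the scatter) when it replaces 5-chloro-2-methoxyphenyl, and an at least 1.4-fold lower number from compound 1 to compound 3 (0.15 log units; that floor lies within the scatter) when it replaces 3-fluorophenyl. These figures are floors rather than measured gaps, so the true differences could be larger, but neither floor reaches beyond the scatter, and the step between the two earlier compounds cannot be read at all, because both sit at the same limit: the limit of > 100000 nM in this assay, at which 2 of the 3 values shown sit.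

The compounds shown leave open whether the reading of compound 3 goes with the five-membered ring itself or with its chlorine, a question that a plain thiophen-2-yl group, or a thiophene carrying a methyl group or a carboxylic acid where the chlorine stands, could help to settle. They also leave open how far any change to the shared core, such as adding an amine, would move the number.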